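Sulfonyl aryl swap in the quinoline sulfone series

The compounds below may be only part of what the source reports. "The series", "measured", "known", "first", "only" and "open" are said of these compounds alone.

Three compounds of the shared core have numbers in an ADME assay on microsomes from liver (Homo sapiens) for metabolic stability, tested at 2.5 uM; a lower number here means slower removal, a higher number faster removal of the compound. Compound 1 `O=S(=O)(c1cc(Cl)cc(Cl)c1)c1cnc2c(F)cccc2c1-c1ccc(F)cc1` gives 1.01 mL/min in this assay, compound 2 `O=S(=O)(c1cc(F)cc(F)c1)c1cnc2c(F)cccc2c1-c1ccc(Cl)cc1` gives 0.73 mL/min, and compound 3 `Cc1ccc(S(=O)(=O)c2cnc3c(F)cccc3c2-c2ccc(Cl)cc2)cc1F` gives 2.2 mL/min. Compound 3 stands highest of the three in this assay: compound 1 is nearest, with a lower number beyond the scatter, and compound 2 is furthest, also beyond the scatter.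

Compound 4 `O=S(=O)(c1cc(Cl)cc(Cl)c1)c1cnc2c(F)cccc2c1-c1ccc(Cl)cc1` differs from compound 3 at one place: 3,5-dichlorophenyl in place of 3-fluoro-4-methylphenyl on a sulfonyl sulfur. Within the data shown here, one measured step bears on this position on the sulfonyl sulfur: a 3.0-fold higher number from compound 2 to compound 3 (0.48 log units; beyond the scatter). Among the measured compounds shown here, the change from compound 3 to compound 4 runs the other way, away from the 3-fluoro-4-methylphenyl group and toward a dihalogenated ring; compound 1 carries the same 3,5-dichlorophenyl on a sulfonyl sulfur and gives 1.01 mL/min, though its other ring differs, so no step to it is counted. A drop back toward the numbers of compound 1 and compound 2 is therefore expected, beyond the scatter but modest.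

For compound 4 in this assay the expected step is a 2.2-fold lower number from compound 3 to compound 4 (0.34 log units; beyond the scatter). Compound 4 is estimated at 1 mL/min in this assay, within a range from 0.5 mL/min to 2 mL/min.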

Compound 4, intrinsic clearance in a liver preparation (reported as CLH), per the amount of preparation that the assay uses: 0.78 mL/min
Estimate against measurement, compound 4: 1.3-fold (0.11 log units) above, and the stated range covers the measured number.
By their numbers in this assay, from the lowest: compounds 2, 4 and 1 (each within the scatter of the next); then compound 3.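

In this assay the 3-fluoro-4-methylphenyl group on a sulfonyl sulfur now stands apart from two dihalogenated rings rather than one: the change to 3,5-dichlorophenyl gives a 2.8-fold lower number from compound 3 to compound 4 (0.45 log units; beyond the scatter) and so matches in size, with opposite direction, the earlier 3.0-fold higher number from compound 2 to compound 3 (0.48 log units; beyond the scatter) on the same position. The two halogens on this ring make no readable difference here, as the swap of 3,5-difluorophenyl for 3,5-dichlorophenyl gives a 1.1-fold higher number from compound 2 to compound 4 (0.03 log units; within the scatter) and stays within the scatter. The change of fluoro to chloro on an aromatic carbon, the other place varied, gives a 1.3-fold lower number from compound 1 to compound 4 (0.11 log units; within the scatter) and is also within the scatter, so among these pairs only the step to or from compound 3 can be read as a real shift, and no listed compound goes against this.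

Nothing at hand explains why the 3-fluoro-4-methylphenyl group stands apart. Going by these compounds, it remains open whether the methyl or the fluoro of that group carries the shift, and whether a ring bearing a methoxy, an amine or a carboxylic acid on a sulfonyl sulfur would sit with compound 4 or with compound 3.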